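A few compounds are considered here, and "the series" means these few. Any claim that something is new, unique, unknown or untested is made for them only; others in the source may bear on it.

Of the compounds shown here, three have been measured. Compound 1 `CC1(C)CC(=O)Nc2ccc(Cl)cc21` carries a carbonyl in its ring; compound 2 `CCNC1=Nc2ccc(Cl)cc2C(C)(C)C1` replaces that carbonyl with an ethylamine group; compound 3 `CC1(C)CC(NCCCCO)=Nc2ccc(Cl)cc21` extends that chain to a 4-hydroxybutyl group. In a functional assay on MDA-MB-231 cells (Homo sapiens) for cytotoxicity, read by MTT assay, with a stated time of 72 h, tested at 5 uM, in the absence of a further agent (a lower number here means a stronger effect, a higher number a weaker effect of the compound at the concentration tested), compound 1 gives 81.7%, compound 2 gives 85.1%, and compound 3 gives 84.9%. All three numbers lie within the usual scatter of one another, so none can be called stronger or weaker; compound 3 sits among them, closest to compound 2 and furthest from compound 1, with both gaps inside the scatter. Among the measured compounds shown here, the one step that can be read, a number 0.2 percentage points lower from compound 2 to compound 3 (within the scatter), shows that lengthening the chain with a hydroxyl-bearing tail left the number unchanged.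

Compound 4 `CC1(C)CC(NCc2ccccc2)=Nc2ccc(Cl)cc21` is the next member. Its difference from compound 3 is phenyl in place of 3-hydroxypropyl on a saturated chain carbon bound to an amine nitrogen. For the measured compounds named here, no measured step exchanges a hydroxyalkyl chain for an aromatic ring, so there is no direct precedent; the only step at a neighbouring place, from compound 2 to compound 3, stayed within the scatter. On that basis compound 4 is expected to show a number 1.9 percentage points lower from compound 3 to compound 4 (within the scatter), that is, no change beyond the scatter. Compound 4 is therefore estimated at 83%, within a range from 68% to 96%, in this assay.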

Compound 4, a percentage reported as activity, at one concentration (the size of the read-out at that concentration, not a potency): 68.1%
For compound 4 the middle estimate is 14.9 percentage points above the measured one, within the range that was stated.
By their numbers in this assay, from the lowest: compound 4; then compounds 1, 3 and 2 (each within the scatter of the next).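

Among the compounds shown here, compound 4 brings the first step beyond the scatter in this assay: exchanging 3-hydroxypropyl for phenyl gives a number 16.8 percentage points lower from compound 3 to compound 4 (beyond the scatter) on the chain carbon bound to the amine nitrogen, and exchanging methyl for phenyl at the same place gives a number 17 percentage points lower from compound 2 to compound 4 (beyond the scatter) in the same direction. The earlier chains, with and without a hydroxyl group, could not be told apart, yet the phenyl ring separates compound 4 from both, so this position on the shared core can change the effect at the concentration tested, and an aromatic ring in place of an open chain is the change that does so here. Nothing in the data explains why the number moves with this exchange.

The compounds shown leave open whether the aromatic ring itself matters, which a saturated ring such as cyclohexylmethyl in place of benzyl could test. They also leave open how far the ring can sit from the amine nitrogen and what groups it can carry, questions that a longer link such as 2-phenylethyl, or a benzyl bearing a methoxy group or a chlorine, would address.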